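Phenyl to pyridinyl on the shared core

A few compounds are considered here, and "the series" means these few. Any claim that something is new, unique, unknown or untested is made for them only; others in the source may bear on it.

Working notes on the series. Compound 1 `CN1CCN(c2cn(S(=O)(=O)c3ccccc3)c3ccccc23)CC1` gives 4 nM in an assay on isolated protein for displacement of a labelled ligand from 5-hydroxytryptamine receptor 6 (Homo sapiens), read by scintillation counting, with a stated time of 1 h; on this read-out higher numbers stand for weaker inhibition and lower numbers for stronger inhibition. Compound 2 `CC(=O)N1CCN(c2cn(S(=O)(=O)c3ccccc3)c3ccccc23)CC1` gives 97 nM in this assay, and compound 3 `O=S(=O)(c1ccccc1)n1cc(-c2ccccc2)c2ccccc21` gives 146 nM, the highest number of the three measured. The step of a 24-fold higher number from compound 1 to compound 2 (1.38 log units; beyond the scatter) and the step of a 37-fold higher number from compound 1 to compound 3 (1.56 log units; beyond the scatter) are both large; the step of a 1.5-fold higher number from compound 2 to compound 3 (0.18 log units; within the scatter) is small.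

Compound 4 `O=S(=O)(c1ccccc1)n1cc(-c2ccncc2)c2ccccc21` differs from compound 3 in one place: pyridin-4-yl in place of phenyl on an aromatic carbon. For the measured compounds named here, no measured step exchanges one six-membered aromatic ring for another; the large steps both concern the loss of the 4-methylpiperazin-1-yl group, and the step from compound 2 to compound 3 shows that swapping the 4-acetylpiperazin-1-yl group for phenyl changes little. The change to compound 4 is therefore not covered by any measured step, and a step within the scatter is expected, with the direction left open; the expected step is a 1.1-fold lower number from compound 3 to compound 4 (0.05 log units; within the scatter). For compound 4 an inhibition constant of 130 nM is estimated in this assay, within a range of 40 nM to 450 nM.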

Compound 4, inhibition constant: 124 nM
The estimate for compound 4 lay 1.0-fold (0.02 log units) above the measured number; measured number inside the range.
By their numbers in this assay, from the lowest: compound 1; then compounds 2, 4 and 3 (each within the scatter of the next).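

In this assay, pyridin-4-yl in place of phenyl on this aromatic carbon gives a 1.2-fold lower number from compound 3 to compound 4 (0.07 log units; within the scatter) and so adds a ring nitrogen and a hydrogen-bond acceptor with no step beyond the scatter. The pyridin-4-yl group also stays within the scatter of the 4-acetylpiperazin-1-yl group, with a 1.3-fold higher number from compound 2 to compound 4 (0.11 log units; within the scatter) on record, whereas a 31-fold higher number from compound 1 to compound 4 (1.49 log units; beyond the scatter) is large; among the four groups shown on this carbon, only the 4-methylpiperazin-1-yl group of compound 1 stands apart. No evidence is available that bears on this result.

The compounds shown leave open whether piperazin-1-yl with a free ring amine would read like the 4-methylpiperazin-1-yl group on this carbon. They also leave open whether pyridin-3-yl or pyridin-2-yl would stay within the scatter of pyridin-4-yl.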